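The source may hold more compounds than are shown below. What is called first, only, known or untested is meant among the compounds shown, and "the series" means these compounds.

In a functional assay on U-373MG ATCC cells for inhibition, with U373 MG (Homo sapiens) as the target, read by MTT assay, with a stated time of 7 days (on this read-out higher numbers stand for weaker inhibition of growth and lower numbers for stronger inhibition of growth), compound 1 `C#CCn1nnc2c(C(N)=O)ncn2c1=O` gives 37600 nM. Compound 2 `NC(=O)c1ncn2c(=O)n(Cc3ccccc3)nnc12` gives no number, only a limit of the assay, > 50000 nM. This is the limit of > 50000 nM in this assay, at which 1 of the 2 values shown sits.

Compound 3 `COc1ccc(Cn2nnc3c(C(N)=O)ncn3c2=O)cc1` keeps the shared core and the phenyl of compound 2 and alters one spot: methoxy in place of hydrogen on an aromatic carbon. In words, this is methoxy in place of hydrogen on an aromatic carbon, para to a large group.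

For the measured compounds named here, no measured step tests methoxy itself. Going by the values given here, the closest evidence is the one measured step, which places phenyl in place of ethynyl on the chain carbon, the same part of the molecule that the new change touches. Its size is known only as a floor, and it is an at least 1.3-fold higher number from compound 1 to compound 2 (0.12 log units; that floor lies within the scatter). Among the compounds with values here, with that single step as the only guide, no shift beyond the scatter is expected in this assay, and no direction can be favoured.

The estimated change is a number no higher from compound 2 to compound 3 (the limit leaves the size open). For compound 3 the expected value is 50000 nM, with an estimated range of 25000 nM to 100000 nM, and a report of only a limit would be no surprise.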

Compound 3, concentration for 50% growth inhibition: > 50000 nM
Compound 3 was reported as a limit; the forecaster's own chance of this, stated with the estimate: 60%; the middle value lies on the limit itself.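

Compound 2 and compound 3 are each reported only as a limit in this assay, so the step between them cannot be read: the limit of > 50000 nM in this assay, at which 2 of the 3 values shown sit.

The compounds shown leave open whether methoxy in place of hydrogen on an aromatic carbon shifts growth inhibition in either direction.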